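The compounds below may be only part of what the source reports. "The series", "measured", "known", "first", "only" and "open" are said of these compounds alone.

The series shares the core of compound 1 `CCOC(=O)c1cn(C(c2ccccc2)c2cc3cc(Br)ccc3nc2OC)nn1` and varies only the arm on the five-membered ring. In an ADME assay on HeLa cells (Homo sapiens) for cytotoxicity, read by sulforhodamine B assay, with a stated time of 48 h, tested at 10 uM (on this read-out lower numbers stand for less inhibition and higher numbers for more inhibition at the one concentration tested (going by the name of the read-out)), compound 1 gives -3.67%, compound 2 `COc1nc2ccc(Br)cc2cc1C(c1ccccc1)n1cc(CCCO)nn1` gives 11.3%, and compound 3 `COc1nc2ccc(Br)cc2cc1C(c1ccccc1)n1cc(-c2ccc(OC(F)(F)F)cc2)nn1` gives -2.24%. Compound 3 stands second highest of the three numbers, within the scatter of compound 1; against compound 2 the change is a number 13.5 percentage points lower from compound 2 to compound 3 (beyond the scatter). Compound 4 `COc1nc2ccc(Br)cc2cc1C(c1ccccc1)n1cc(CCO)nn1` differs from compound 3 by 2-hydroxyethyl in place of 4-(trifluoromethoxy)phenyl on an aromatic carbon. The step that bears on this is a number 13.5 percentage points lower from compound 2 to compound 3 (beyond the scatter), read in reverse, with 3-hydroxypropyl and 2-hydroxyethyl being near relatives; a number 15 percentage points higher from compound 1 to compound 2 (beyond the scatter) points the same way. A modest rise in this assay is therefore expected, a number 10.2 percentage points higher from compound 3 to compound 4 (beyond the scatter). For compound 4 the estimated value is 8%, ranging from -5% to 20%.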

Compound 4, a percentage reported as inhibition, at one concentration (the size of the read-out at that concentration, not a potency): 0.85%
For compound 4 the middle estimate is 7.2 percentage points above the measured one, and the stated range covers the measured number.
By their numbers in this assay, from the lowest: compounds 1, 3 and 4 (each within the scatter of the next); then compound 2.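

In this assay, a hydroxy-bearing chain on this aromatic carbon does not by itself raise the number: the change gives a number 3.1 percentage points higher from compound 3 to compound 4 (within the scatter) and a number 4.5 percentage points higher from compound 1 to compound 4 (within the scatter), so 2-hydroxyethyl cannot be told apart from 4-(trifluoromethoxy)phenyl or ethoxycarbonyl. The chain length does register, with a number 10.5 percentage points lower from compound 2 to compound 4 (beyond the scatter), which leaves 3-hydroxypropyl as the only arm set apart from the other three. No measurement at hand explains this difference.

Still open, going by these compounds, is whether a longer chain such as 4-hydroxybutyl would hold or exceed the number of compound 2, 11.3%. Also open, on these data alone, is whether an amine or a carboxylic acid in place of the hydroxy would do the same.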